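This account rests on a few compounds, and the source may have more. Where it says the series, first, only, none or still open, it means among the compounds named here.

Of the compounds shown here, three have been measured so far in an assay on HEK293 cells for displacement of a labelled ligand from 5-hydroxytryptamine receptor 4 (Homo sapiens), read by scintillation counting; a higher number here means a weaker inhibitor, a lower number a stronger inhibitor. Compound 1 `COc1cc(N)c(Cl)cc1C(=O)NCC1CCNCC1` gives 316 nM in this assay. Compound 2 `CC(C)n1c(=O)n(C(=O)NCC2CCNCC2)c2ccccc21` gives 39.8 nM in this assay. Compound 3 `CCCCCN1CCC(NC(=O)c2cc(Cl)c(N)cc2OC)CC1` gives 100 nM in this assay. Among these three numbers compound 3 stands second highest: its nearest neighbour is compound 2, whose number is lower by a margin beyond the usual scatter of repeated measurements, and its furthest neighbour is compound 1, whose number is higher, again beyond the scatter.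

Compound 4 `COc1cc(N)c(Cl)cc1C(=O)NC1CCN(CCCCCN2CCCCC2)CC1` has not yet been measured in this assay. It differs from compound 3 in a single place: piperidin-1-yl in place of hydrogen on a saturated chain carbon, five bonds along the chain from an amine nitrogen in a ring. Going by the values given here, no pair of measured compounds differing in only one place is available, so the size of such a step cannot be read from the numbers at hand, and any expectation must rest on compound 3 alone together with the nature of the change. The step is expected to be a 2.5-fold lower number from compound 3 to compound 4 (0.40 log units; beyond the scatter), a modest move toward a lower number in this assay, of a size that may just pass beyond the scatter. On that basis compound 4 is estimated at 40 nM in this assay, within a range from 12 nM to 130 nM.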

Compound 4, inhibition constant: 10 nM
Estimate against measurement, compound 4: 4.0-fold (0.60 log units) above, outside the stated range (below it).
By their numbers in this assay, from the lowest: compound 4; then compound 2; then compound 3; then compound 1.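

Placing piperidin-1-yl on a saturated chain carbon, five bonds along the chain from an amine nitrogen in a ring, gives a 10-fold lower number from compound 3 to compound 4 (1.00 log units; beyond the scatter) in this assay and is the first change in this series that can be read on its own. The step shows that this far end of the chain is not a neutral place for substitution, since a single added ring moves the number well beyond the usual scatter and in the direction of a stronger inhibitor. No measurement offered here explains why this position responds in this way, and the size of the step stands as an observation without a stated cause.

On these data alone, what remains open is whether the ring as a whole or its amine nitrogen carries the step, a question that a cyclohexyl group, a morpholin-4-yl group or a simple dimethylamino group at the same chain end would help to settle. The compounds shown also leave unresolved how the step depends on the distance from the ring nitrogen, which a shorter or a longer chain ending in the same piperidin-1-yl group would address.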